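Swapping phenyl for cyclohexyl on the core of compound 1

The compounds below may be only part of what the source reports. "The series", "measured", "known", "first", "only" and "open" are said of these compounds alone.

This account follows a single change made to compound 1, whose structure is `O=C(O)c1ccccc1-c1ccc(CCc2ncc(-c3ccccc3)[nH]2)cc1`. Within the data shown here, in an in vitro functional assay on cells for agonist activity at Bombesin receptor subtype-3 (Mus musculus), read by luminescence and calcium flux (a higher number here means that more compound is needed for the effect, a lower number that less compound is needed), compound 1 gives 872 nM, the highest of the three numbers measured so far. Compound 2, `COc1ccc(Cc2cnc(CCc3ccc(-c4ccccc4C(=O)O)cc3)[nH]2)cc1`, gives 513 nM, and the step of a 1.7-fold lower number from compound 1 to compound 2 (0.23 log units; within the scatter). Compound 3, `O=C(O)c1ccccc1-c1ccc(CCc2ncc(Cc3cccc(F)c3F)[nH]2)cc1`, gives 8 nM, and the step of a 110-fold lower number from compound 1 to compound 3 (2.04 log units; beyond the scatter); the step of a 64-fold lower number from compound 2 to compound 3 (1.81 log units; beyond the scatter).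

The new compound is compound 4, `O=C(O)c1ccccc1-c1ccc(CCc2ncc(C3CCCCC3)[nH]2)cc1`, which differs from compound 1 as follows: cyclohexyl in place of phenyl on an aromatic carbon.

Among the measured compounds shown here, none of the measured steps replaces phenyl with a non-aromatic ring, so no step bears directly on this change. The two steps measured at this position both put a benzyl group in place of phenyl, one within the scatter and one large. The change to compound 4 keeps the same count of heavy atoms and the same attachment to the ring, but trades an aromatic ring for a saturated one, and the closest measured change, compound 1 to compound 2, was within the scatter. A modest step in either direction, or none beyond the scatter, is therefore expected for compound 4, with the estimated step of a 1.5-fold lower number from compound 1 to compound 4 (0.16 log units; within the scatter). The estimate for compound 4 in this assay is 600 nM, in the range 150 nM to 3000 nM.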

Compound 4, half-maximal effective concentration: 14.7 nM
Estimate against measurement, compound 4: 41-fold (1.61 log units) above, and the stated range ends above it.
By their numbers in this assay, from the lowest: compounds 3 and 4 (each within the scatter of the next); then compounds 2 and 1 (each within the scatter of the next).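

Compound 4 shows that at this carbon, next to the ring nitrogen, phenyl and cyclohexyl are not interchangeable despite their equal count of heavy atoms: the change from an aromatic to a non-aromatic six-membered ring gives a 59-fold lower number from compound 1 to compound 4 (1.77 log units; beyond the scatter) in this assay. The earlier compounds shown here reached low numbers only through 2,3-difluorobenzyl, whereas cyclohexyl, attached directly to the ring, lands within the scatter of that group, with a 1.8-fold higher number from compound 3 to compound 4 (0.26 log units; within the scatter), and remains well separated from 4-methoxybenzyl, with a 35-fold lower number from compound 2 to compound 4 (1.54 log units; beyond the scatter). No measurement shown here accounts for why the saturated ring and the 2,3-difluorobenzyl group fall together while phenyl and 4-methoxybenzyl fall together.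

The compounds shown leave open whether ring size matters at this position, since they do not say how a cyclopentyl or cycloheptyl ring, or a piperidine ring carrying an amine nitrogen, would compare with cyclohexyl. They also leave open whether a ring is needed here at all, which an open chain such as n-hexyl would test, and how an unsubstituted benzyl group would stand against 2,3-difluorobenzyl and 4-methoxybenzyl.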